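Amide substituent variation in a hydroxamate series

A few compounds are considered here, and "the series" means these few. Any claim that something is new, unique, unknown or untested is made for them only; others in the source may bear on it.

Measured compounds:
compound 1 `O=C(CCCCCCn1cc(C(=O)NCc2ccc(Cl)cc2)c2ccccc21)NO` gives 1.56 nM in an assay on isolated protein for inhibition of protein deacetylase HDAC6 (Homo sapiens), read by fluorescence, with a stated time of 60 min; on this read-out lower numbers stand for stronger inhibition and higher numbers for weaker inhibition
compound 2 `O=C(CCCCCCn1cc(C(=O)Nc2ccc(Cl)cc2Cl)c2ccccc21)NO` gives 3.73 nM in this assay
compound 3 `O=C(CCCCCCn1cc(C(=O)NC2CCCCC2)c2ccccc21)NO` gives 2.32 nM in this assay

Compound 3 stands second highest of the three numbers, yet both of its neighbours lie within the scatter: a 1.5-fold higher number from compound 1 to compound 3 (0.17 log units; within the scatter) and a 1.6-fold lower number from compound 2 to compound 3 (0.21 log units; within the scatter). Every step measured so far is an exchange on the same amide-type nitrogen, and none of them moves the number far.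

Compound 4 `O=C(CCCCCCn1cc(C(=O)NC2CCCCCC2)c2ccccc21)NO` is the next member. It differs from compound 3 as follows: cycloheptyl in place of cyclohexyl on an amide-type nitrogen. Going by the values given here, the steps that bear on this change are the two just named, each within the scatter, so for compound 4 no step beyond the scatter is expected, a 1.0-fold lower number from compound 3 to compound 4 (0.00 log units; within the scatter). Compound 4 is therefore estimated at 2.3 nM in this assay, with a range from 1.1 nM to 4.8 nM.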

Compound 4, half-maximal inhibitory concentration: 2.11 nM
Estimate against measurement, compound 4: 1.1-fold (0.04 log units) above; measured number inside the range.
By their numbers in this assay, from the lowest: compounds 1, 4, 3 and 2 (each within the scatter of the next, the first and the last beyond it).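

In this assay, cycloheptyl in place of cyclohexyl on the amide-type nitrogen adds one ring carbon without a step beyond the scatter (a 1.1-fold lower number from compound 3 to compound 4 (0.04 log units; within the scatter)). Cycloheptyl also stays within the scatter of both other substituents (a 1.8-fold lower number from compound 2 to compound 4 (0.25 log units; within the scatter); a 1.4-fold higher number from compound 1 to compound 4 (0.13 log units; within the scatter)), so among these four compounds only the exchange between compound 1 and compound 2 is printed as beyond it. Nothing available gives a reason for this narrow spread.

Still open, as far as these compounds go, is whether cyclopropyl, or a cycloheptyl ring carrying a carboxylic acid or an amine, would keep the number in this range.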